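The source may report more compounds than this note shows. Statements on the series, on what has been measured and on what is new or still open speak of the compounds shown alone.

Measured so far:
Compound 1 `COc1ccc([C@@H]2C/C(=N/OCc3cn(-c4ccc(C#N)cc4)nn3)c3cc(CC=C(C)C)c(OC)cc3O2)cc1`: 50%
Compound 2 `COc1cc2c(cc1CC=C(C)C)C(=O)C[C@@H](c1ccc(Oc3cccc([N+](=O)[O-])c3)cc1)O2`: 46%

In a functional assay on HCT-116 cells (Homo sapiens) for inhibition, read by sulforhodamine B assay, with a stated time of 48 h, tested at 50 uM (on this read-out higher numbers stand for more inhibition of growth at the one concentration tested and lower numbers for less inhibition of growth), compound 2 gives 46% as its reading. That value lies within the usual scatter of compound 1 (50%), so the two cannot be ranked against each other.

Compound 3 `C#CCOc1ccc([C@@H]2CC(=O)c3cc(CC=C(C)C)c(OC)cc3O2)cc1` has not yet been measured. It keeps the core of compound 2 and differs in one place: propargyl in place of 3-nitrophenyl on an oxygen on an aromatic ring. An aromatic ring therefore leaves, and a short chain with a triple bond enters.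

Within the data shown here, no two measured compounds differ in just one place, so no measured step shows what a swap like this does. The expectation in this assay is therefore a small downward move at most, with no step beyond the scatter. It rests only on compound 2 (46%) as the starting point, and the wide range reflects that thin basis. The estimated change is a number 6 percentage points lower from compound 2 to compound 3 (within the scatter) and would stay within the scatter. For compound 3 the expected value is 40%, with an estimated range from 22% to 60%.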

Compound 3, percent growth inhibition at one concentration: 75%
Estimate against measurement, compound 3: 35 percentage points below, and the stated range ends below it.
By their numbers in this assay, from the lowest: compounds 2 and 1 (each within the scatter of the next); then compound 3.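

In this assay, among these compounds, replacing 3-nitrophenyl with propargyl on an oxygen on an aromatic ring gives a number 29 percentage points higher from compound 2 to compound 3 (beyond the scatter) and is the only step here between compounds that differ in one place. It shows that the group on this oxygen can change the reading: 9 heavy atoms with an aromatic ring leave, 3 heavy atoms with no ring and a triple bond enter, and growth inhibition rises, which the earlier pair, compound 1 and compound 2, could not show because they differ in more than one place. No measurement at hand explains why the reading rises.

The compounds shown leave open which part of the change matters: the loss of the nitro group, the loss of the aromatic ring, or the arrival of the triple bond. A plain phenyl, a methyl or a saturated propyl chain on the same oxygen would help separate these three possibilities, since each keeps or removes only some of these features.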